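Sulfonamide variation on a shared core in rat aorta

A few compounds are considered here, and "the series" means these few. Any claim that something is new, unique, unknown or untested is made for them only; others in the source may bear on it.

Measured compounds:
Compound 1, `CC1(C)C=C(n2ccccc2=O)c2cc(S(=O)(=O)NCc3ccccc3)ccc2O1`: 71.1%
Compound 2, `CN(C)S(=O)(=O)c1ccc2c(c1)C(n1ccccc1=O)=CC(C)(C)O2`: 78.3%

In a functional assay on the whole organism (aorta) with Rattus norvegicus as the target (on this read-out lower numbers stand for smaller maximal responses and higher numbers for larger maximal responses), compound 2 gives 78.3%, and in this assay compound 1 gives 71.1%; the two numbers lie within the scatter of each other, as the step of a number 7.2 percentage points higher from compound 1 to compound 2 (within the scatter) shows, so neither compound can be set above the other. Compound 3, `CC1(C)C=C(n2ccccc2=O)c2cc(S(=O)(=O)NC(=O)Nc3ccccc3)ccc2O1`, has not yet been measured in this assay. It differs from compound 2 in one place: (phenylcarbamoyl)amino in place of dimethylamino on a sulfonyl sulfur. For the measured compounds named here, the only measured step that bears on this change is the exchange at the same sulfonyl sulfur, a number 7.2 percentage points higher from compound 1 to compound 2 (within the scatter), which stayed within the scatter. On that basis the step of a number 5.3 percentage points lower from compound 2 to compound 3 (within the scatter) is expected to be small, in no firm direction. The maximal response of compound 3 in this assay is therefore estimated at 73%, with a range from 55% to 90%.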

Compound 3, largest response reached (Emax), in percent of the reference or control that the assay uses: 90.8%
Compound 3: middle estimate off by 17.8 percentage points, on the low side, and the stated range ends below it.
By their numbers in this assay, from the lowest: compounds 1 and 2 (each within the scatter of the next); then compound 3.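

In this assay, the exchange at the sulfonyl sulfur now moves the maximal response beyond the scatter: (phenylcarbamoyl)amino in place of dimethylamino gives a number 12.5 percentage points higher from compound 2 to compound 3 (beyond the scatter). Phenylcarbamoyl in place of benzyl on the sulfonamide nitrogen gives a number 19.7 percentage points higher from compound 1 to compound 3 (beyond the scatter), so a six-membered aromatic ring at this place, present in both compounds, does not alone set the level reached by compound 3. Nothing available here accounts for the higher response of compound 3.

The compounds shown leave open whether the phenyl ring or the carbonyl-bearing link carries this step. An acetyl or a methylcarbamoyl group on the sulfonamide nitrogen would separate the two, and a simple amino group at the sulfonyl sulfur would show the level without any such substituent.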